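This account rests on a few compounds, and the source may have more. Where it says the series, first, only, none or still open, it means among the compounds named here.

Compound 1 `CCCOC(=O)Nc1ccc([Se]C#N)cc1`: 51900 nM in a functional assay on HT-29 cells (Homo sapiens) for cytotoxicity, read by MTT assay, with a stated time of 72 h; a higher number here means a weaker inhibitor of growth, a lower number a stronger inhibitor of growth. Compound 2 `CCCCOC(=O)Nc1ccc([Se]C#N)cc1`: 31300 nM. Compound 3 `CCOC(=O)Nc1ccc([Se]C#N)cc1`: 38000 nM.

Among these three numbers compound 3 holds the second highest; its nearest neighbour is shown by a 1.2-fold higher number from compound 2 to compound 3 (0.08 log units; within the scatter) and its furthest by a 1.4-fold lower number from compound 1 to compound 3 (0.14 log units; within the scatter), both within the scatter. Compound 4 `N#C[Se]c1ccc(NC(=O)Oc2ccccc2)cc1` differs from compound 3 by phenyl in place of ethyl on an oxygen next to a carbonyl group. Among the measured compounds shown here, the steps that bear on this position are a 1.7-fold lower number from compound 1 to compound 2 (0.22 log units; within the scatter), a 1.4-fold lower number from compound 1 to compound 3 (0.14 log units; within the scatter) and a 1.2-fold higher number from compound 2 to compound 3 (0.08 log units; within the scatter), all changes of a chain on the same oxygen and none beyond the scatter. For the measured compounds named here, no measured step brings a ring in at this place, so the expectation rests on those small alkyl steps alone. Compound 4 is therefore expected to move little, a 1.3-fold lower number from compound 3 to compound 4 (0.10 log units; within the scatter), with an estimated value of 30000 nM and a range from 10000 nM to 90000 nM.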

Compound 4, concentration for total growth inhibition: 41700 nM
Compound 4: the middle estimate sits 1.4-fold (0.14 log units) below what was measured, within the range that was stated.
By their numbers in this assay, from the lowest: compounds 2, 3, 4 and 1 (each within the scatter of the next).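

In this assay, among the compounds shown here, the oxygen next to a carbonyl group carries a ring for the first time, and phenyl in place of ethyl (a 1.1-fold higher number from compound 3 to compound 4 (0.04 log units; within the scatter)), butyl (a 1.3-fold higher number from compound 2 to compound 4 (0.12 log units; within the scatter)) or propyl (a 1.2-fold lower number from compound 1 to compound 4 (0.10 log units; within the scatter)) stays within the scatter. A six-membered aromatic ring of carbon only therefore cannot be told apart here from these three chains on this oxygen. Nothing measured here accounts for this result. The compounds shown leave open whether a benzyl group, a much longer chain or a phenyl ring bearing a methoxy or nitro group would stand apart from these values.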